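Swapping the nitro group for a methoxy group on the ester

This account rests on a few compounds, and the source may have more. Where it says the series, first, only, none or still open, it means among the compounds named here.

Measured so far:
Compound 1 `CC1=CC[C@H](C(C)C)c2cc(C)c(OC(=O)c3ccccc3)cc21`: 60.7%
Compound 2 `CC1=CC[C@H](C(C)C)c2cc(C)c(OC(=O)c3cccc([N+](=O)[O-])c3)cc21`: 29.3%

In a functional assay on MCF7 cells (Homo sapiens) for antiproliferative activity, read by sulforhodamine B assay, with a stated time of 48 h, tested at 50 uM (on this read-out lower numbers stand for less inhibition and higher numbers for more inhibition at the one concentration tested (going by the name of the read-out)), compound 1 gives 60.7%, while compound 2 gives 29.3%. Among the measured compounds shown here, compound 2 therefore holds the lowest of the two numbers, with compound 1 as its only neighbour, and the single measured step, a number 31.4 percentage points lower from compound 1 to compound 2 (beyond the scatter), is a large one.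

Compound 3 `COc1ccc(C(=O)Oc2cc3c(cc2C)[C@@H](C(C)C)CC=C3C)cc1` differs from compound 2 by 4-methoxyphenyl in place of 3-nitrophenyl on a carbonyl carbon. For the measured compounds named here, only the step from compound 1 to compound 2 bears on this change, and it shows that what sits on the phenyl ring of the ester can move the read-out strongly. Nothing measured tells how the 4-methoxyphenyl group itself behaves, so the expectation is a partial return toward compound 1, estimated as a number 20.7 percentage points higher from compound 2 to compound 3 (beyond the scatter). Compound 3 is thus expected to give about 50%, with a range from 25% to 75%.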

Compound 3, a percentage reported as inhibition, at one concentration (the size of the read-out at that concentration, not a potency): 80.1%
The estimate for compound 3 lay 30.1 percentage points below the measured number, outside the stated range (above it).
By their numbers in this assay, from the lowest: compound 2; then compound 1; then compound 3.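

Until now, a group added to the phenyl ring of the ester had only lowered the read-out, but in this assay methoxy in place of hydrogen gives a number 19.4 percentage points higher from compound 1 to compound 3 (beyond the scatter), so a change here can also raise it. The exchange of 3-nitrophenyl for 4-methoxyphenyl on the carbonyl carbon gives a number 50.8 percentage points higher from compound 2 to compound 3 (beyond the scatter), but it alters both the group and its place on the ring, so these two changes cannot be told apart. Nothing available explains why these groups differ in this way.

Going by these compounds, it remains open whether the gain belongs to the methoxy group itself or to its place on the ring, which 3-methoxyphenyl and 4-nitrophenyl esters would help to separate. On these data alone, it is also open how an amine, a carboxylic acid or a longer chain such as butoxy would behave on this ring.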